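This account rests on a few compounds, and the source may have more. Where it says the series, first, only, none or still open, it means among the compounds named here.

The measured compounds and their numbers in a functional assay on PANC-1 cells (Homo sapiens) for inhibition, read by MTT assay, with a stated time of 24 h, tested at 10 uM; on this read-out higher numbers stand for more inhibition at the one concentration tested (going by the name of the read-out) and lower numbers for less inhibition:

compound 1, `CC(C)=CCC1Cc2c(OCCCNS(=O)(=O)c3ccc(Cl)cc3)cc(=O)n(CCCO)c2CC1(C)C`, gives 24.7%
compound 2, `COc1ccc(OCCCOc2cc(=O)n(CCCO)c3c2CC(CC=C(C)C)C(C)(C)C3)cc1`, gives 47.7%
compound 3, `CC(C)=CCC1Cc2c(OCCCOc3ccc(Cl)cc3)cc(=O)n(CCCO)c2CC1(C)C`, gives 22.7%

Compound 3 stands lowest of the three in this assay, though only just: the step of a number 2 percentage points lower from compound 1 to compound 3 (within the scatter) is within the scatter, so compounds 1 and 3 cannot be told apart, while compound 2 is clearly set apart, as the step of a number 25 percentage points lower from compound 2 to compound 3 (beyond the scatter) shows.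

Compound 4, `CC(C)=CCC1Cc2c(OC(=O)Nc3ccc(Cl)c(Cl)c3)cc(=O)n(CCCO)c2CC1(C)C`, is the next compound to be tested in this assay. It differs from compound 3 in one place: (3,4-dichlorophenyl)carbamoyl in place of 3-(4-chlorophenoxy)propyl on an oxygen on an aromatic ring.

All three measured steps concern the group attached through this same ring oxygen. Two of them swapped the group at the far end of the chain: a number 23 percentage points higher from compound 1 to compound 2 (beyond the scatter) and a number 2 percentage points lower from compound 1 to compound 3 (within the scatter). The third swapped one substituent on the outer ring: a number 25 percentage points lower from compound 2 to compound 3 (beyond the scatter). Going by the values given here, only the step that introduced methoxy moved the number beyond the scatter; the others left it where it was. Among the compounds with values here, the change to compound 4 is larger than any of these, removing the chain altogether, so no measured step matches it closely. On that basis compound 4 is expected to stay near compound 3, with the step of a number 4.3 percentage points higher from compound 3 to compound 4 (within the scatter) estimated to lie within or just beyond the scatter. The estimate for compound 4 is 27%, with a range from 10% to 48%.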

Compound 4, a percentage reported as inhibition, at one concentration (the size of the read-out at that concentration, not a potency): 61.4%
Compound 4: middle estimate off by 34.4 percentage points, on the low side; measured number outside the range, above it.
By their numbers in this assay, from the lowest: compounds 3 and 1 (each within the scatter of the next); then compound 2; then compound 4.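

At the oxygen on the aromatic ring, putting (3,4-dichlorophenyl)carbamoyl in place of 3-(4-chlorophenoxy)propyl gives a number 38.7 percentage points higher from compound 3 to compound 4 (beyond the scatter) in this assay, the largest step in this small set. Going by these compounds alone, the earlier steps changed only the far end of a chain attached through this oxygen, so this is the first sign that replacing the whole group can move the number more than those end swaps did. The two groups hold the same number of heavy atoms and one aromatic ring each, but the entering group adds a nitrogen, a second chlorine, a double bond outside the ring and a hydrogen-bond donor, and no measurement available here explains the rise.

Several features changed in this single step, so the compounds shown cannot say whether the higher number follows the carbamoyl link or the second chlorine, and (4-chlorophenyl)carbamoyl on the same oxygen would separate those two. A (4-methoxyphenyl)carbamoyl group would test whether the higher number seen with methoxy in the chain series carries over to this link.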